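The source may hold more compounds than are shown below. What is called first, only, known or untested is meant among the compounds shown, and "the series" means these compounds.

In a functional assay on KARPAS-422 cells (Homo sapiens) for antiproliferative activity, read by resazurin assay, with a stated time of 72 h (on this read-out lower numbers stand for stronger inhibition and higher numbers for weaker inhibition), compound 1 (`COC(c1cc(Cl)c2c(c1Cl)C(=O)N(Cc1c(C)cc(C)[nH]c1=O)CC2)C1CCS(=O)(=O)CC1`) gives 970 nM; 24 nM (2 entries), two entries that lie far apart. Within the data shown here, compound 2 (`Cc1cc(C)c(CN2CCc3c(Cl)cc([C@@H](CO)[C@@H]4CCOC4)c(Cl)c3C2=O)c(=O)[nH]1`) gives 3950 nM, the only number it has in this assay, and a further entry for it carries no single number. That value is higher than both entries of compound 1, so compound 2 stands on the side of weaker inhibition among the numbers shown.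

Compound 3 (`Cc1cc(C)c(CN2CCc3c(Cl)cc([C@@H](CO)[C@H]4CCCO4)c(Cl)c3C2=O)c(=O)[nH]1`) has yet to be measured. It has the same atoms as compound 2, joined differently: oxolan-2-yl in place of oxolan-3-yl on a saturated chain carbon bound to an aromatic carbon and a saturated chain carbon. Among the measured compounds shown here, no measured pair isolates this change, so any expectation is loose. With compound 2 at 3950 nM, a moderate move towards stronger inhibition is expected rather than a further loss. The estimated change is a 2.6-fold lower number from compound 2 to compound 3 (0.42 log units; beyond the scatter), and it may not prove larger than the usual scatter. The expected range stays wide because the several entries of compound 1 in this assay, 970 nM; 24 nM (2 entries) show how far separate entries for one compound can fall apart. For compound 3 the estimated value is 1500 nM, with an expected range from 300 nM to 6500 nM.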

Compound 3, half-maximal inhibitory concentration: 535 nM
Estimate against measurement, compound 3: 2.8-fold (0.45 log units) above; the range from low to high includes it.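

In this assay, the place on a saturated chain carbon bound to an aromatic carbon and a saturated chain carbon proves sensitive to how the ring is attached, not only to which atoms it carries: oxolan-2-yl in place of oxolan-3-yl gives a 7.4-fold lower number from compound 2 to compound 3 (0.87 log units; beyond the scatter). The two groups match in every count given, namely heavy atoms, hydrogen-bond donors and acceptors, charge and defined stereocentres, so this step comes with no change in composition. It remains a single pair, however, and it has to be read against how far separate entries for one compound can lie apart in this assay: the several entries of compound 1 in this assay, 970 nM; 24 nM (2 entries).

The compounds shown leave open whether the step depends on the ring oxygen at all, a question that a cyclopentyl group or an amine such as pyrrolidin-2-yl in the same place would address. They also leave open what the opposite configuration at the defined stereocentre of the oxolan-2-yl group would give, and whether a larger ring such as oxan-2-yl would follow the same direction.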